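A few compounds are considered here, and "the series" means these few. Any claim that something is new, unique, unknown or untested is made for them only; others in the source may bear on it.

Compound 1, with the structure `O=C(O)CC/C=C\C[C@@H]1CN(Cc2cccnc2)C[C@@H]1c1ccccc1O`, is the weaker of the two measured compounds: in a functional assay (Cavia porcellus) for antagonist activity at thromboxane A2 receptor (Homo sapiens) (on this read-out lower numbers stand for tighter binding and higher numbers for weaker binding), compound 1 gives 1580 nM. Compound 2, `O=C(O)CC/C=C\C[C@@H]1CN(S(=O)(=O)c2cccc3ccccc23)C[C@@H]1c1ccccc1O`, carries a different group on the same ring nitrogen and in this assay compound 2 gives 1.59 nM, a far lower number than compound 1, a gap well beyond the scatter of repeated runs. The two values show that what sits on this nitrogen can move the result a long way.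

Compound 3, `CC(C)C(=O)N1C[C@@H](C/C=C\CCC(=O)O)[C@@H](c2ccccc2O)C1`, has not been measured. It differs from compound 1 in one place: isopropylcarbonyl in place of (pyridin-3-yl)methyl on an amine nitrogen in a ring. Among the measured compounds shown here, no measured pair shows exactly this exchange, so the size of the step can only be guessed. Since the group on this nitrogen is where compound 1 and compound 2 part ways by such a wide margin, a change there is expected to matter, and the replacement is expected to lower the number, though not as far as compound 2 reaches. The step from a 5.3-fold lower number from compound 1 to compound 3 (0.72 log units; beyond the scatter) is the expected outcome. Compound 3 is thus estimated at 300 nM, with a likely range from 60 nM to 1500 nM.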

Compound 3, dissociation constant: 200 nM
Beside the measured number, compound 3's estimate is 1.5-fold (0.18 log units) above it; the range from low to high includes it.
By their numbers in this assay, from the lowest: compound 2; then compound 3; then compound 1.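

In this assay, putting isopropylcarbonyl in place of (pyridin-3-yl)methyl on the amine nitrogen in the ring gives a 7.9-fold lower number from compound 1 to compound 3 (0.90 log units; beyond the scatter), so this nitrogen responds to a change far smaller than the one separating the first two compounds. The entering group has fewer heavy atoms than the one it replaces and no ring, which shows that a ring in this group is not required for a lower number, yet compound 3 gives 200 nM while compound 2 gives 1.59 nM, so this exchange covers only part of the span seen at this position. No measurement at hand explains why the number falls.

The exchange alters both the carbonyl link to the nitrogen and the group carried on it, so the compounds shown cannot tell which of the two matters more. An acetyl or a benzoyl group on the same nitrogen would help to separate these two parts, and a benzyl group would show whether the pyridine nitrogen of compound 1 plays any part in its high number.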